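The source may report more compounds than this note shows. Statements on the series, on what has been measured and on what is new or still open speak of the compounds shown alone.

Measured so far:
Compound 1 `COc1cc(C)cc(-c2c(-c3ccnc(-c4ccc(C(C)=O)cc4)c3)cnn2CC#N)c1` gives 30%.
Compound 2 `Cc1cc(O)cc(-c2nn(CC#N)cc2-c2ccnc(-c3ccc(Oc4ccccc4)cc3)c2)c1` gives -83%.
Compound 3 `Cc1cc(O)cc(-c2nn(CC#N)cc2-c2ccnc(-c3ccc(N(C)C)cc3)c2)c1` gives 9%.

All three were tested in a functional assay on OVCAR-4 cells (Homo sapiens) for cytotoxicity, read by sulforhodamine B assay, with a stated time of 48 h, tested at 10 uM; a lower number here means a stronger effect, a higher number a weaker effect of the compound at the concentration tested. Among them, compound 1 stands highest of the three numbers, which here means the weakest effect at the concentration tested: its nearest neighbour is compound 3, and compound 2 lies furthest away, both gaps beyond the scatter.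

The unmeasured compound 4 `COc1cc(C)cc(-c2c(-c3ccnc(-c4ccc(N(C)C)cc4)c3)cnn2CC#N)c1` differs from compound 1 in one place: dimethylamino in place of acetyl on an aromatic carbon. Among the compounds with values here, only one measured step touches the same entering group, the step of a number 92 percentage points higher from compound 2 to compound 3 (beyond the scatter), where dimethylamino replaced phenoxy rather than acetyl, so it bears on the present change only loosely. Within the data shown here, compound 3, the dimethylamino-bearing analogue, gives a lower number than compound 1, but those two also differ in a second place, so no single step links them.

Given this, a modest move downward or none beyond the scatter is expected; the estimated step is a number 10 percentage points lower from compound 1 to compound 4 (within the scatter), and compound 4 is expected to give about 20%, within a range from -5% to 45%.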

Compound 4, a percentage reported as activity, at one concentration (the size of the read-out at that concentration, not a potency): 25%
For compound 4 the middle estimate is 5 percentage points below the measured one; measured number inside the range.
By their numbers in this assay, from the lowest: compound 2; then compound 3; then compounds 4 and 1 (each within the scatter of the next).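

In this assay, putting dimethylamino in place of acetyl on this aromatic carbon, para to a large group, gives a number 5 percentage points lower from compound 1 to compound 4 (within the scatter), so on the core of compound 1 these two groups cannot be told apart. The earlier change at this position gave a number 92 percentage points higher from compound 2 to compound 3 (beyond the scatter), so the group here can matter a great deal when phenoxy is the group leaving, although that step sits on a core with a different substitution. No measurement shown here offers an explanation for either result.

From the compounds shown here alone, it remains open whether phenoxy on the core of compound 1 would give a number as low as compound 2 gives, at -83%. Going by these compounds, the effect of a carboxylic acid or a longer amine chain at this position also remains open.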